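This account rests on a few compounds, and the source may have more. Where it says the series, first, only, none or still open, it means among the compounds named here.

Measured compounds:
Compound 1 `CCC[C@@]1(O)[C@@H](CO)O[C@@H](n2ccc(=O)[nH]c2=O)[C@@H]1O` gives > 350000 nM in a functional assay on L1210 cells (Mus musculus), read by MTT assay; on this read-out higher numbers stand for weaker inhibition and lower numbers for stronger inhibition; this is a limit of the assay, not a number.
Compound 2 `O=c1ccn([C@@H]2O[C@H](CO)[C@](O)(C3CC3)[C@H]2O)c(=O)[nH]1` gives > 350000 nM; this too is a limit.
Compound 3 `C=C[C@@]1(O)[C@@H](CO)O[C@@H](n2ccc(=O)[nH]c2=O)[C@@H]1O` gives 148000 nM.

Among the compounds with values here, compound 3 thus holds the only actual number among the three values; the other two sit at the limit of > 350000 nM in this assay, at which 2 of the 3 values shown sit. From compound 1 to compound 3 the change was an at least 2.3-fold lower number from compound 1 to compound 3 (0.37 log units; beyond the scatter), and from compound 2 to compound 3 it was an at least 2.3-fold lower number from compound 2 to compound 3 (0.37 log units; beyond the scatter), while a step that the two limits leave unreadable from compound 1 to compound 2.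

Compound 4 `CC#C[C@@]1(O)[C@@H](CO)O[C@@H](n2ccc(=O)[nH]c2=O)[C@@H]1O` differs from compound 3 in one place: prop-1-yn-1-yl in place of vinyl on a saturated ring carbon. Within the data shown here, no measured step covers this exact change. The two readable steps show that vinyl gave a lower number than propyl or cyclopropyl, each at least modest in size. A three-carbon chain without a ring has so far given only a limit, so a move back toward that outcome cannot be excluded, yet the triple bond is new here. Compound 4 is therefore expected to give a number near that of compound 3, with a 1.3-fold lower number from compound 3 to compound 4 (0.13 log units; within the scatter) as the expected step, and an estimated value of 110000 nM (range 25000 nM to 350000 nM).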

Compound 4, half-maximal inhibitory concentration: 354000 nM
For compound 4 the middle estimate is 3.2-fold (0.51 log units) below the measured one; the measured number lies above the stated range.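

In this assay, the step of a 2.4-fold higher number from compound 3 to compound 4 (0.38 log units; beyond the scatter) is a modest one, but it shows that a triple bond on this saturated ring carbon does not keep the lower number seen with vinyl. Among the four compounds, compound 3 keeps the lowest number, so having a multiple bond at this position is not enough by itself, and the double bond of vinyl and the triple bond of prop-1-yn-1-yl cannot be treated as interchangeable. The steps from compound 1 and compound 2 to compound 4 cannot be read, because those two compounds give only a limit: the limit of > 350000 nM in this assay, at which 2 of the 4 values shown sit.

This step changes the bond and the chain length together, so the two effects cannot be separated. As far as these compounds go, an ethynyl group would test the triple bond without the added carbon, and a longer chain or an amine at this position remains unexplored.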